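This account rests on a few compounds, and the source may have more. Where it says the series, first, only, none or still open, it means among the compounds named here.

Compound 1 `COC(=O)C1=CO[C@@H](O[C@@H]2O[C@H](COC(c3ccccc3)(c3ccccc3)c3ccccc3)[C@@H](OC(=O)O)[C@H](OC(C)=O)[C@H]2OC(C)=O)[C@@H]2[C@@H](C)[C@@H](OC(C)=O)C[C@H]12`: 1.2 ug/mL
Compound 2 `COC(=O)C1=CO[C@@H](O[C@@H]2O[C@H](CO)[C@@H](OC(C)=O)[C@H](OC(C)=O)[C@H]2OC(C)=O)[C@@H]2[C@@H](C)[C@@H](OC(C)=O)C[C@H]12`: "not active" (no number reported)

In a functional assay on MCF7 cells (Homo sapiens) for cytotoxicity, read by MTT assay, with a stated time of 4 h (on this read-out lower numbers stand for stronger inhibition and higher numbers for weaker inhibition), compound 1 gives 1.2 ug/mL. Compound 2 has no single number on this scale, because compound 2 is reported only as "not active" (no number reported). It therefore serves as an inactive starting point, not as a numerical baseline.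

Compound 3 `C=CC(=O)OC[C@H]1O[C@@H](O[C@@H]2OC=C(C(=O)OC)[C@H]3C[C@H](OC(C)=O)[C@H](C)[C@@H]23)[C@H](OC(C)=O)[C@@H](OC(C)=O)[C@@H]1OC(C)=O` has not yet been measured. The structural change is vinylcarbonyl in place of hydrogen on an oxygen on a saturated carbon: vinylcarbonyl takes the place of hydrogen on an oxygen on a saturated carbon, so hydroxymethyl becomes ((vinylcarbonyl)oxy)methyl.

For the measured compounds named here, no measured pair isolates this change, so the size of the step cannot be read from the data. A move towards stronger inhibition is expected, from no number to a measurable one, but with low confidence. Going by the values given here, the only support is compound 1, which also carries a group on that oxygen, differs elsewhere too, and gives 1.2 ug/mL. A second report of no activity remains possible.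

For compound 3, the estimated value in this assay is 4 ug/mL, with an expected range from 0.8 ug/mL to 20 ug/mL.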

Compound 3, half-maximal inhibitory concentration: "not active" (no number reported)
For compound 3 the study gives words and no number; the estimate stays without a comparison.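

Compound 2 and compound 3 are both reported only as not active in this assay, and no step can be read between them. No measured evidence accounts for this result. The compounds shown leave open which structural differences from these two go with the measurable value of compound 1 , 1.2 ug/mL.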